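The source may report more compounds than this note shows. Statements on the series, on what has been measured and on what is new or still open speak of the compounds shown alone.

Three compounds, all built on one shared core, have been tested for how much they harm a human cell line. Compound 1 `CCCNc1nc(Nc2ccc(C#N)cc2)nc(Oc2cccc3ccccc23)n1` carries a propylamino group, compound 2 `CNc1nc(Nc2ccc(C#N)cc2)nc(Oc2ccc3ccccc3c2Br)n1` a methylamino group, and compound 3 `CCNc1nc(Nc2ccc(C#N)cc2)nc(Oc2ccc3ccccc3c2Cl)n1` an ethylamino group, each beside a differently substituted naphthyloxy part. In an ADME assay on MT4 cells (Homo sapiens) for cytotoxicity, read by MTT assay, with a stated time of 4 days (on this read-out higher numbers stand for lower toxicity in this test and lower numbers for higher toxicity in this test), compound 1 gives 29500 nM. In this assay compound 2 gives 143000 nM, and compound 3 gives 188000 nM. Compound 3 therefore stands at the highest number of the three, meaning the lowest toxicity seen here; its gap to compound 2 is within the usual scatter, so the two cannot be ranked against each other, while its gap to compound 1 is beyond the scatter.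

Compound 4 `N#Cc1ccc(Nc2nc(N=[N+]=[N-])nc(Oc3ccc4ccccc4c3Cl)n2)cc1` has not been measured yet. It differs from compound 3 in a single change: azido in place of ethylamino on an aromatic carbon. Within the data shown here, no pair of measured compounds differs in just this way, so there is no measured step to lean on. Given that all three measured numbers sit in a weakly toxic region, compound 4 is expected to give 100000 nM, with a range from 30000 nM to 300000 nM. The expected step is a 1.9-fold lower number from compound 3 to compound 4 (0.27 log units; within the scatter), a modest move toward higher toxicity that may well fall within the scatter.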

Compound 4, half-maximal cytotoxic concentration: 256000 nM
Compound 4: the middle estimate sits 2.6-fold (0.41 log units) below what was measured, within the range that was stated.
By their numbers in this assay, from the lowest: compound 1; then compounds 2, 3 and 4 (each within the scatter of the next).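

In this assay, putting azido in place of ethylamino on the aromatic carbon between two ring nitrogen atoms gives a 1.4-fold higher number from compound 3 to compound 4 (0.13 log units; within the scatter), so the two compounds cannot be told apart. Among these compounds, this is the first measured pair in the set that differs in one place only, and it shows that this position can take a group with three nitrogen atoms and no hydrogen-bond donor in place of one with two carbons, one nitrogen and a donor, with no readable shift in this read-out. Nothing measured here explains why the number stays put.

The compounds shown leave open whether other groups at this position, such as a plain amine, a hydroxyl group or a longer chain like butylamino, would also leave the number unmoved. As far as these compounds go, it also remains open whether the same swap would behave alike with the other naphthyloxy parts seen in compound 1 and compound 2, and the lower number of compound 1 cannot be traced to any single change, since it differs from the others in more than one place.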